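A few compounds are considered here, and "the series" means these few. Any claim that something is new, unique, unknown or untested is made for them only; others in the source may bear on it.

Compound 1, `CNC(=O)c1cc(Oc2ccc3nc(Nc4ccc(C(F)(F)F)cc4)ncc3c2)ccn1`: < 1 10^-6 cm/s
Compound 2, `CNC(=O)c1cc(Oc2ccc3nc(Nc4ccc(OC)cc4)ncc3c2)ccn1`: < 1 10^-6 cm/s

In an ADME assay on Caco-2 cells (Homo sapiens) for permeability, in the apical to basolateral direction (a lower number here means that the compound crosses the layer more slowly, a higher number that the compound crosses the layer faster), compound 1 gives < 1 10^-6 cm/s, a limit of the assay and not a number. Compound 2 gives < 1 10^-6 cm/s, likewise a limit. Compound 2 therefore stands at the limit of < 1 10^-6 cm/s in this assay, at which 2 of the 2 values shown sit. Within the data shown here, the one measured step, a step that the two limits leave unreadable from compound 1 to compound 2, cannot be read. Compound 3, `CNC(=O)c1cc(Oc2ccc3nc(Nc4ccc(OC(F)(F)F)cc4)ncc3c2)ccn1`, differs from compound 2 by trifluoromethyl in place of methyl on an oxygen on an aromatic ring. With no readable step to draw on, the expected change in this assay is a step that the limit leaves unreadable from compound 2 to compound 3, none beyond the scatter. Compound 3 is estimated at 0.5 10^-6 cm/s, in the range 0.15 10^-6 cm/s to 1.5 10^-6 cm/s.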

Compound 3, apparent permeability: < 1 10^-6 cm/s
Compound 3 gave a limit, no number; the forecaster's own chance of this, stated with the estimate: 70%; the middle value lies beyond the limit too.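

Among these compounds, no step among compound 1, compound 2 and compound 3 can be read in this assay, since each value is a limit and not a number: (the limit of < 1 10^-6 cm/s in this assay, at which 3 of the 3 values shown sit). The compounds shown leave open how fast any of the three crosses the layer, and whether their differing groups change that rate at all.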